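Thiazole to trifluorophenyl swap on two related fused cores

A few compounds are considered here, and "the series" means these few. Any claim that something is new, unique, unknown or untested is made for them only; others in the source may bear on it.

Measured compounds:
compound 1, `O=C1CCCC2=C1C(c1ccc(F)cc1Cl)N=C(c1nccs1)N2`, 47700 nM
compound 2, `CC1(C)CC(=O)C2=C(C1)NC(c1nccs1)=NC2c1ccc(F)cc1Cl`, 57000 nM
compound 3, `O=C1CCCC2=C1C(c1ccc(F)cc1Cl)N=C(c1c(F)cc(F)cc1F)N2`, 123000 nM

All three were tested in an ADME assay on HepG2 2.2.15 cells (Homo sapiens) for cytotoxicity; on this read-out lower numbers stand for stronger inhibition and higher numbers for weaker inhibition. Compound 1 gives 47700 nM, and compound 3, which carries the change (2,4,6-trifluorophenyl in place of 1,3-thiazol-2-yl on a carbon with a double bond to nitrogen), gives 123000 nM; this is a step of a 2.6-fold higher number from compound 1 to compound 3 (0.41 log units; beyond the scatter). Compound 2 gives 57000 nM, which lies within the scatter of compound 1. The difference between the core of compound 1 and the core of compound 2 is not broken down here.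

Compound 4, `CC1(C)CC(=O)C2=C(C1)NC(c1c(F)cc(F)cc1F)=NC2c1ccc(F)cc1Cl`, has not been measured. It carries the change 2,4,6-trifluorophenyl in place of 1,3-thiazol-2-yl on a carbon with a double bond to nitrogen relative to compound 2, the same change as from compound 1 to compound 3. Among the measured compounds shown here, since the only measured instance of this change gave a 2.6-fold higher number from compound 1 to compound 3 (0.41 log units; beyond the scatter), a step of similar size is expected for compound 4 in this assay, namely a 2.6-fold higher number from compound 2 to compound 4 (0.41 log units; beyond the scatter), resting on a single precedent and therefore uncertain. Compound 4 is estimated at 148000 nM, with a range from 70000 nM to 300000 nM.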

Compound 4, half-maximal inhibitory concentration: 5600 nM
Estimate against measurement, compound 4: 26-fold (1.42 log units) above; measured number below the stated range.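

In this assay, the change from 1,3-thiazol-2-yl to 2,4,6-trifluorophenyl did not carry over from one core to the other: on the second core it gave a 10-fold lower number from compound 2 to compound 4 (1.01 log units; beyond the scatter), which is opposite in direction to the earlier step. Set side by side, the two instances disagree: the same change on two cores in this assay, a 2.6-fold higher number (0.41 log units; beyond the scatter) from compound 1 to compound 3 and a 10-fold lower number (1.01 log units; beyond the scatter) from compound 2 to compound 4, 26-fold (1.42 log units) apart, beyond the scatter of two such steps This shows that, in these four compounds, the outcome of the change depends on the core that carries it, but with a single pair on each core it does not show which feature of the cores is responsible, nor what the change would do on any further core.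

The compounds shown leave open whether a core with only one methyl group would behave like the core of compound 1 or the core of compound 2. They also leave open how a simple phenyl or a pyridin-2-yl group would behave on the carbon with a double bond to nitrogen on either core.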